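Trifluoromethoxy for trifluoromethyl: expectation for compound 4

This account rests on a few compounds, and the source may have more. Where it says the series, first, only, none or still open, it means among the compounds named here.

Going by the values given here, compound 2 `COC(=O)c1scc(-c2ccc(NC(=O)c3cccc(C(F)(F)F)c3)cc2)c1OC` gives 6130 nM in a functional assay on K562 cells (Homo sapiens) for antiproliferative activity, read by MTT assay, with a stated time of 24 h (on this read-out higher numbers stand for weaker inhibition and lower numbers for stronger inhibition), the lowest of the three numbers measured so far. Compound 1 `COC(=O)c1scc(-c2ccc(NC(=O)c3cc(I)ccc3F)cc2)c1OC` gives 35600 nM and compound 3 `COC(=O)c1scc(-c2ccc(NC(=O)c3ccccn3)cc2)c1OC` gives 24200 nM; both a 5.8-fold lower number from compound 1 to compound 2 (0.76 log units; beyond the scatter) and a 3.9-fold higher number from compound 2 to compound 3 (0.60 log units; beyond the scatter) lie beyond the scatter, whereas a 1.5-fold lower number from compound 1 to compound 3 (0.17 log units; within the scatter) does not. Compound 4 `COC(=O)c1scc(-c2ccc(NC(=O)c3cccc(OC(F)(F)F)c3)cc2)c1OC` differs from compound 2 by trifluoromethoxy in place of trifluoromethyl on an aromatic carbon. Among the compounds with values here, no measured step alters a single group on that ring; the measured steps exchange the whole ring on the carbonyl carbon, and their size gives no direct guide to this smaller change. The step of a 1.3-fold higher number from compound 2 to compound 4 (0.12 log units; within the scatter) is therefore expected to stay within the scatter. Compound 4 is estimated at 8000 nM, in the range 3000 nM to 25000 nM.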

Compound 4, half-maximal inhibitory concentration: 18300 nM
The estimate for compound 4 lay 2.3-fold (0.36 log units) below the measured number; the measured number falls inside the stated range.
By their numbers in this assay, from the lowest: compound 2; then compounds 4, 3 and 1 (each within the scatter of the next).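

In this assay, going by these compounds alone, the exchange of trifluoromethyl for trifluoromethoxy gives a 3.0-fold higher number from compound 2 to compound 4 (0.47 log units; beyond the scatter) and is the first single-group change on this ring, so this aromatic carbon is not indifferent to even a small exchange. Compound 2 remains the most potent of the four compounds, with the trifluoromethyl group the best of the substituents seen here. Nothing available bears on the cause of this step. Open, going by these compounds, is how a methoxy group, an amine or a carboxylic acid on the same aromatic carbon would read, and whether this step carries over to other rings on the carbonyl.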